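Furan-2-yl in Place of 3-Fluorophenyl: Expected Solubility

This account rests on a few compounds, and the source may have more. Where it says the series, first, only, none or still open, it means among the compounds named here.

The set shares one core, carrying an aryl group on an aromatic carbon of a five-membered aromatic ring with 2 nitrogen, part of a fused system of two rings. Compound 1 `Cc1cc(NCc2nccs2)n2nc(C)c(-c3ccccc3)c2n1` gives 108000 nM in a physicochemical assay for solubility, read by HPLC, using the shake flask method, measured as kinetic solubility, with a stated time of 2 h, at pH 7.4; a lower number here means a less soluble compound, a higher number a more soluble compound. Compound 2 `Cc1cc(NCc2ccc3ccccc3n2)n2nc(C)c(-c3ccccc3)c2n1` gives only a limit of the assay in this assay, < 5000 nM, and that is all its entry shows (the limit of < 5000 nM in this assay, at which 1 of the 3 values shown sits). Compound 3 `Cc1cc(NCc2ccccn2)n2ncc(-c3cccc(F)c3)c2n1` gives 5000 nM in this assay, which is the lowest of the two numbers shown; the nearest number, that of compound 1, is higher by a margin that lies beyond the usual scatter.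

Compound 4 `Cc1cc(NCc2ccccn2)n2ncc(-c3ccco3)c2n1` has not yet been measured. It differs from compound 3 in one place: furan-2-yl in place of 3-fluorophenyl on an aromatic carbon. Within the data shown here, no step between two measured compounds matches this change, so its effect can only be guessed. Compound 4 is expected to sit somewhat higher than compound 3 in this assay, with the step from a 1.6-fold higher number from compound 3 to compound 4 (0.20 log units; within the scatter) expected to be small and probably within the scatter. On that basis compound 4 is estimated at 8000 nM in this assay, with a likely range from 3000 nM to 25000 nM.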

Compound 4, solubility: 48800 nM
The estimate for compound 4 lay 6.1-fold (0.79 log units) below the measured number, and the stated range ends below it.
By their numbers in this assay, from the lowest: compound 3; then compound 4; then compound 1.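

At this position, an aromatic carbon of a five-membered aromatic ring with 2 nitrogen, two ring bonds from the ring nitrogen, the group carried matters in this assay: furan-2-yl in place of 3-fluorophenyl gives a 9.8-fold higher number from compound 3 to compound 4 (0.99 log units; beyond the scatter). Among these compounds, the earlier compounds could not show this, as no two of them differed in one place, so this pair gives the first reading of any single change in the set, and that reading lies beyond the usual scatter. No measurement shown here bears on what lies behind a step of this size.

Because this is the only step at this position, the compounds shown leave open whether it belongs to furan-2-yl itself or would also appear with another group there, such as thiophen-2-yl, pyridin-3-yl or an unsubstituted phenyl. They also leave open whether the same change would give a step of similar size in the other compounds of the set, such as compound 1, which differ from compound 3 in more than one place.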